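Chloro in place of hydrogen on compound 2

A few compounds are considered here, and "the series" means these few. Any claim that something is new, unique, unknown or untested is made for them only; others in the source may bear on it.

Working notes on the series. In a functional assay on V79 cells (Cricetulus griseus) for cytotoxicity, read by colony formation (a higher number here means a weaker inhibitor, a lower number a stronger inhibitor), read as a half-maximal inhibitory concentration, compound 1 `O=C(O)c1cn(C2CC2)c2c(Cl)c(N3CCCC3)c(F)cc2c1=O` gives 150 ug/mL and compound 2 `CNCC1(C)CCN(c2cc3c(cc2F)c(=O)c(C(=O)O)cn3C2CC2)C1` gives 205 ug/mL. These two values lie within the scatter of each other, so they set no order.

Compound 3 `CNCC1(C)CCN(c2c(F)cc3c(=O)c(C(=O)O)cn(C4CC4)c3c2Cl)C1` differs from compound 2 by a single change: chloro in place of hydrogen on an aromatic carbon, ortho to the 3-methyl-3-((methylamino)methyl)pyrrolidin-1-yl group.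

Going by the values given here, no measured pair isolates this change. Among the compounds with values here, the only guide is compound 1, which also carries a chloro group and gives 150 ug/mL. In this assay, no shift beyond the scatter is expected, with a slight lean towards a lower number. The expected step is a 1.4-fold lower number from compound 2 to compound 3 (0.14 log units; within the scatter). Compound 3 is estimated at 150 ug/mL, with an expected range of 65 ug/mL to 340 ug/mL.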

Compound 3, half-maximal inhibitory concentration: 23 ug/mL
For compound 3 the middle estimate is 6.5-fold (0.81 log units) above the measured one; measured number outside the range, below it.
By their numbers in this assay, from the lowest: compound 3; then compounds 1 and 2 (each within the scatter of the next).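

In this assay, chloro in place of hydrogen on an aromatic carbon, ortho to the 3-methyl-3-((methylamino)methyl)pyrrolidin-1-yl group, gives an 8.9-fold lower number from compound 2 to compound 3 (0.95 log units; beyond the scatter), so this position responds to the change when that group is present. With chloro held in place, 3-methyl-3-((methylamino)methyl)pyrrolidin-1-yl in place of pyrrolidin-1-yl on an aromatic carbon gives a 6.5-fold lower number from compound 1 to compound 3 (0.81 log units; beyond the scatter), a contribution that compound 1 and compound 2 could not show, as they differ in two places. Nothing in hand bears on the cause of either step.

Whether the first step is specific to chloro remains open, since a bromo, methyl or methoxy group on this carbon is not among the compounds shown. Also open, going by these compounds, is whether chloro has a similar effect alongside pyrrolidin-1-yl.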